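A few compounds are considered here, and "the series" means these few. Any claim that something is new, unique, unknown or untested is made for them only; others in the source may bear on it.

Compound 1 `Nc1ccc2cccc(OCC3CCCC3)c2n1` is the starting point of this account; in an assay on cells with melanin-concentrating hormone receptor 1 (Homo sapiens) as the target, read by radioligand binding (on this read-out higher numbers stand for weaker inhibition and lower numbers for stronger inhibition), compound 1 gives 53 nM, the lower of the two numbers in hand. Among the measured compounds shown here, compound 2 `Nc1ccc2cccc(OC3CCCCCC3)c2n1` is the only other measured analogue, and in this assay compound 2 gives 137 nM, a weaker result beyond the usual scatter. Compound 3 `COCCOCCOc1cccc2ccc(N)nc12` is not yet measured; it differs from compound 1 by (2-methoxyethoxy)methyl in place of cyclopentyl on a saturated chain carbon bound to an oxygen on an aromatic ring. For the measured compounds named here, no measured step of this kind exists, so the change is expected to weaken inhibition in this assay by a step of a 5.7-fold higher number from compound 1 to compound 3 (0.75 log units; beyond the scatter). Compound 3 is therefore estimated at 300 nM, in a range from 80 nM to 1500 nM.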

Compound 3, half-maximal inhibitory concentration: > 2000 nM
Compound 3: no number, only a limit (the forecaster's own chance of this, stated with the estimate: 10%); middle value at least 6.6-fold (0.82 log units) away from the limit.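

Among the compounds shown here, compound 3 gives the first measured change of an open ether chain for a ring at this place: (2-methoxyethoxy)methyl in place of cyclopentyl gives an at least 37-fold higher number from compound 1 to compound 3 (1.57 log units; beyond the scatter), a large step towards weaker inhibition in this assay. The value of compound 3 is a limit and not a number: the limit of > 2000 nM in this assay, at which 1 of the 3 values shown sits. This place therefore does not accept every group in this assay.

Compound 3 removes the ring and brings in two ether oxygens at once, so the compounds shown do not tell which of these changes matters. A plain hexyl chain or a tetrahydropyranyl ring would separate the two.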